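Swapping pyridin-3-yl for pyridin-4-yl in a permeability series

The compounds below may be only part of what the source reports. "The series", "measured", "known", "first", "only" and "open" are said of these compounds alone.

Of the compounds shown here, three sharing one core have been tested in an ADME assay on Caco-2 cells (Homo sapiens) for permeability, in the apical to basolateral direction; on this read-out higher numbers stand for higher permeability and lower numbers for lower permeability. Compound 1 `COC(=O)N[C@H](C(=O)NN(CCC[C@@](O)(Cc1ccccc1)C(=O)N[C@H]1c2ccccc2C[C@H]1O)Cc1ccccc1)C(C)(C)C` gives < 20 10^-6 cm/s, which is a limit and not a number. Compound 2 `COC(=O)N[C@H](C(=O)NN(CCC[C@@](O)(Cc1ccccc1)C(=O)N[C@H]1c2ccccc2C[C@H]1O)Cc1ccc(-c2nccs2)cc1)C(C)(C)C`, carrying 1,3-thiazol-2-yl on an aromatic carbon, gives > 20 10^-6 cm/s, also a limit. Compound 3 `COC(=O)N[C@H](C(=O)NN(CCC[C@@](O)(Cc1ccccc1)C(=O)N[C@H]1c2ccccc2C[C@H]1O)Cc1ccc(-c2cccnc2)cc1)C(C)(C)C`, with pyridin-3-yl at that place, gives < 20 10^-6 cm/s, again a limit. Compound 3 therefore has no exact figure and stands at the limit of < 20 10^-6 cm/s in this assay, at which 2 of the 3 values shown sit.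

Compound 4 `COC(=O)N[C@H](C(=O)NN(CCC[C@@](O)(Cc1ccccc1)C(=O)N[C@H]1c2ccccc2C[C@H]1O)Cc1ccc(-c2ccncc2)cc1)C(C)(C)C` has the same atoms as compound 3, joined differently: pyridin-4-yl in place of pyridin-3-yl on an aromatic carbon, para to a large group (pyridin-4-yl in place of pyridin-3-yl on an aromatic carbon).

Three measured steps form the background: a number no lower from compound 1 to compound 2 (the limit leaves the size open), a step that the two limits leave unreadable from compound 1 to compound 3 and a number no higher from compound 2 to compound 3 (the limit leaves the size open). The limits leave the size of all three open, and none of them exchanges one pyridinyl group for another. They therefore offer no size to carry over to the new change. The expectation rests on the closest relative, compound 3, at < 20 10^-6 cm/s.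

The expected change is a step that the limit leaves unreadable from compound 3 to compound 4, nothing beyond the usual scatter.

For compound 4 the estimated value is 14 10^-6 cm/s, with an expected range from 5 10^-6 cm/s to 35 10^-6 cm/s.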

Compound 4, apparent permeability: < 20 10^-6 cm/s
Compound 4 ended at the assay's limit; the forecaster's own chance of this, stated with the estimate: 80%; the middle value does not contradict the limit.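

With pyridin-4-yl in place of pyridin-3-yl on this aromatic carbon, para to a large group, compound 4 stays on the same side of the limit as compound 3 in this assay, so this exchange of one pyridinyl group for the other brings no move across that limit: the limit of < 20 10^-6 cm/s in this assay, at which 3 of the 4 values shown sit. The change from 1,3-thiazol-2-yl to pyridin-4-yl at the same place gives a number no higher from compound 2 to compound 4 (the limit leaves the size open), which matches the direction already seen with pyridin-3-yl, and the 1,3-thiazol-2-yl compound remains alone on the other side of the limit: the limit of > 20 10^-6 cm/s in this assay, at which 1 of the 4 values shown sits. All of these values are limits and not numbers, and the steps that link compound 4 to compound 3 and to compound 1 cannot be read.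

As far as these compounds go, how far compound 1, compound 3 and compound 4 lie from one another stays open, as does the distance of any of them from the limit. Also open, from the compounds shown here alone, is how this assay would read with a 1,3-oxazol-2-yl ring, an amine or a carboxylic acid on this same aromatic carbon.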